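A pyrrolidinyl amino group on the sulfonyl sulfur

This account rests on a few compounds, and the source may have more. Where it says the series, first, only, none or still open, it means among the compounds named here.

Compound 1 `CN1CCC(CNS(=O)(=O)c2ccccc2Nc2cc(-c3ccc4ccn(C)c4c3)c3nccnc3c2)C1` gives 0.633 h
Compound 2 `CN(C)S(=O)(=O)c1ccccc1Nc1cc(-c2ccc3ccn(C)c3c2)c2nccnc2c1` gives 0.233 h

In an ADME assay on microsomes from liver (Mus musculus, strain CD-1) for metabolic stability, read by LC-MS, tested at 2 uM (on this read-out higher numbers stand for a longer-lived compound and lower numbers for a shorter-lived compound), compound 2 at 0.233 h holds the lower of the two numbers. Compound 3 `CN1CCC(NS(=O)(=O)c2ccccc2Nc2cc(-c3ccc4ccn(C)c4c3)c3nccnc3c2)C1` remains unmeasured and differs from compound 2 by (1-methylpyrrolidin-3-yl)amino in place of dimethylamino on a sulfonyl sulfur in a single exchange, (1-methylpyrrolidin-3-yl)amino in place of dimethylamino on a sulfonyl sulfur. Among the compounds with values here, the one measured step bearing on this is a 2.7-fold lower number from compound 1 to compound 2 (0.43 log units; beyond the scatter) where dimethylamino replaced ((1-methylpyrrolidin-3-yl)methyl)amino on the sulfur. Compound 3 runs the opposite way with a similar ring-bearing group, so a modest rise is expected, with a 2.1-fold higher number from compound 2 to compound 3 (0.33 log units; beyond the scatter) as the estimated step. For compound 3 the expected half-life is 0.5 h within an estimated range of 0.25 h to 1 h overall.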

Compound 3, half-life: 0.667 h
Estimate against measurement, compound 3: 1.3-fold (0.13 log units) below; the measured number falls inside the stated range.
By their numbers in this assay, from the lowest: compound 2; then compounds 1 and 3 (each within the scatter of the next).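

In this assay, (1-methylpyrrolidin-3-yl)amino on the sulfonyl sulfur gives a 2.9-fold higher number from compound 2 to compound 3 (0.46 log units; beyond the scatter), so the gain over dimethylamino does not depend on the extra chain carbon of compound 1. Exchanging (1-methylpyrrolidin-3-yl)methyl for 1-methylpyrrolidin-3-yl on the sulfonamide nitrogen gives a 1.1-fold higher number from compound 1 to compound 3 (0.02 log units; within the scatter), leaving these two groups indistinguishable here. No measurement on hand accounts for these steps. Still open, on these data alone, is whether the difference from compound 2 goes with the ring, its nitrogen or the sulfonamide hydrogen; a methylamino or cyclopentylamino group on the sulfonyl sulfur would bear on that.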